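The compounds below may be only part of what the source reports. "The series", "measured", "known", "first", "only" and "open" are said of these compounds alone.

Compound 1 `C=C1C(=O)[C@]23C[C@@]1(O)CC[C@H]2c1ccc(OS(=O)(=O)c2ccc(C)cc2)c(C)c1[C@@H]3Cn1cc(-c2ccc(Cl)cc2)nn1` gives the higher of the two numbers available in a functional assay on SW480 cells (Homo sapiens) for cytotoxicity, read by MTT assay, with a stated time of 4 days (on this read-out higher numbers stand for weaker inhibition and lower numbers for stronger inhibition), where compound 1 gives 2390 nM. For the measured compounds named here, compound 2 `C=C1C(=O)[C@]23C[C@@]1(O)CC[C@H]2c1ccc(O)c(C)c1[C@@H]3Cn1cc(-c2ccc(Cl)cc2)nn1` gives 280 nM in this assay, and the only single-point change measured is an 8.5-fold lower number from compound 1 to compound 2 (0.93 log units; beyond the scatter), the removal of the (4-methylphenyl)sulfonyl from the oxygen on the aromatic ring. Compound 3 `C=C1C[C@]23C[C@@]1(O)CC[C@H]2c1cc(Br)c(O)c(C)c1[C@@H]3Cn1cc(-c2ccc(F)cc2)nn1` shows only a limit of the assay, > 20000 nM, the limit that the limit of > 20000 nM in this assay, at which 1 of the 3 values shown sits, describes. Going by the values given here, compound 4 `C=C1C(=O)[C@]23C[C@@]1(O)CC[C@H]2c1ccc(OS(=O)(=O)c2ccc(C)cc2)c(C)c1[C@@H]3Cn1cc(-c2ccc(OC)cc2)nn1` carries methoxy in place of chloro on an aromatic carbon, a change on the phenyl of the triazole, a part of the shared core that no measured step touches. Compound 4 is therefore expected to show no step beyond the scatter, a 1.0-fold higher number from compound 1 to compound 4 (0.00 log units; within the scatter). Compound 4 is estimated at 2400 nM, within a range from 800 nM to 7000 nM.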

Compound 4, half-maximal inhibitory concentration: 1640 nM
Estimate against measurement, compound 4: 1.5-fold (0.17 log units) above; the range from low to high includes it.
By their numbers in this assay, from the lowest: compound 2; then compounds 4 and 1 (each within the scatter of the next). At a limit, above all of these: compound 3.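

In this assay, for the compounds shown here, the first measured change on the phenyl of the triazole, from 4-chlorophenyl to 4-methoxyphenyl, is a 1.5-fold lower number from compound 1 to compound 4 (0.16 log units; within the scatter), so the two compounds cannot be told apart. With the (4-methylphenyl)sulfonyl still on the oxygen, this position therefore accepts methoxy in place of chloro, whereas removing that sulfonyl group gives an 8.5-fold lower number from compound 1 to compound 2 (0.93 log units; beyond the scatter). No available evidence bears on this result.

From the compounds shown here alone, whether the same swap holds with the free hydroxyl of compound 2 remains open. So does whether an amine or a carboxylic acid on this aromatic carbon would give a different number.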